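The source may hold more compounds than are shown below. What is called first, only, known or untested is meant among the compounds shown, and "the series" means these compounds.

Going by the values given here, in a functional assay on MT4 cells (Homo sapiens) for cytotoxicity, read by MTT assay (on this read-out higher numbers stand for lower toxicity in this test and lower numbers for higher toxicity in this test), only two compounds with the shared core have been measured so far. Compound 1 `Cc1c(O)nc(SCc2ccc(Cl)cc2)nc1Cc1c(Cl)cccc1Cl` gives > 59000 nM, which is a limit of the assay and not a number. Compound 2 `Cc1c(O)nc(SCc2ccc(F)cc2)nc1Cc1c(Cl)cccc1Cl` gives > 61000 nM, which is likewise a limit, so compound 2 has no exact value on this read-out. The next compound is compound 3 `Cc1c(O)nc(SCc2cccc(Cl)c2)nc1Cc1c(Cl)cccc1Cl`, and its difference from compound 2 is 3-chlorophenyl in place of 4-fluorophenyl on a saturated chain carbon bound to a sulfur. Among the compounds with values here, the one measured step that bears on this change is a step that the two limits leave unreadable from compound 1 to compound 2, and it has no size that can be read. It therefore offers no support for a shift in either direction, and no step beyond the usual scatter is expected in this assay. Expressed as a step, the estimate is an at least 1.0-fold lower number from compound 2 to compound 3 (0.00 log units; that floor lies within the scatter). For compound 3 the estimated value is 60000 nM, with an expected range from 30000 nM to 100000 nM, and the result is expected most likely to arrive as a limit again.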

Compound 3, half-maximal cytotoxic concentration: > 59000 nM
Compound 3: a limit, no number; the forecaster's own chance of this, stated with the estimate: 80%; the middle value does not contradict the limit.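

In this assay compound 3 gives > 59000 nM, which is a limit of the assay and not a number. Going by these compounds alone, no step among compound 1, compound 2 and compound 3 can be read. The compounds shown leave open where the true values of these three compounds lie, and whether 4-chlorophenyl, 4-fluorophenyl and 3-chlorophenyl differ on this read-out at all.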